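The source may report more compounds than this note shows. Statements on the series, on what has been measured and on what is new or still open speak of the compounds shown alone.

In an ADME assay on microsomes from liver (Homo sapiens) for metabolic stability, with a stated time of 60 min (on this read-out higher numbers stand for a more stable compound and lower numbers for a less stable compound), compound 1 `Cc1ccc(NC(=O)C[C@H](CCC(=O)O)c2noc(-c3cc(CC(C)C)on3)c2C2CC2)c(Cl)c1` gives 74% and compound 2 `Cc1ccc(NC(=O)C[C@H](CCC(=O)O)c2noc(-c3cc(CCC(C)C)on3)c2C2CC2)c(Cl)c1` gives 79%. Among the measured compounds shown here, these two values lie within the scatter of each other, so compound 2 stands level with the only other compound measured so far. The next structure, compound 3 `Cc1ccc(NC(=O)C[C@H](CCC(=O)O)c2noc(-c3cc(CC(C)(C)C)on3)c2C2CC2)c(Cl)c1`, keeps the shared core and alters only the same side chain. It carries tert-butyl in place of isobutyl on a saturated chain carbon bound to an aromatic carbon. Cut one bond further out, the same difference reads isopentyl to neopentyl, and the two compounds have the same atoms, joined differently. For the measured compounds named here, only one measured step bears on this change, and it sits at the same place, with isobutyl in place of isopropyl: a number 5 percentage points higher from compound 1 to compound 2 (within the scatter). Going by the values given here, the data hold no measured example with tert-butyl at this place, so that small step is the only guide, and no shift beyond the scatter is expected in this assay. The expected step is a number 3 percentage points lower from compound 2 to compound 3 (within the scatter). For compound 3 the estimated value is 76%, with an expected range from 62% to 90%.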

Compound 3, percent of the compound remaining: 84%
Compound 3: the middle estimate sits 8 percentage points below what was measured; the measured number falls inside the stated range.
By their numbers in this assay, from the lowest: compounds 1, 2 and 3 (each within the scatter of the next).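

At this place, on a saturated chain carbon bound to an aromatic carbon, tert-butyl now joins isopropyl and isobutyl in this assay without moving the read-out beyond the scatter (a number 5 percentage points higher from compound 2 to compound 3 (within the scatter)). The same holds for the pair that differs by methyl in place of hydrogen on a saturated chain carbon bound to three saturated chain carbons (a number 10 percentage points higher from compound 1 to compound 3 (within the scatter)), so all three side chains tested so far stand level and cannot be ranked, and rearranging the same atoms from isopentyl to neopentyl leaves the result within the scatter. Nothing measured here explains why these side chains stand level.

What the compounds shown leave open is whether this level read-out extends to side chains of another kind at this place, such as a cyclohexyl ring, a phenyl ring, a longer chain ending in a hydroxyl group or one ending in a primary amine. They also leave open whether isobutyl, tert-butyl or any other of these groups would read the same way on a different core.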